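The source may report more compounds than this note shows. Statements on the series, on what has been measured and on what is new or still open speak of the compounds shown alone.

Working notes on the series. Within the data shown here, in a physicochemical assay for acid dissociation, compound 1 (`CO[C@H]1C(=O)N2C(C(=O)c3ccccc3)=C(C)C(Sc3nnnn3C)S(=O)(=O)[C@H]12`) gives 4.8 and compound 2 (`CO[C@H]1C(=O)N2C(C(=O)c3ccccc3)=C(CSc3nnnn3C)C(Sc3nnnn3C)S(=O)(=O)[C@H]12`) gives 3.5 as the lower of the two numbers so far. The next structure is compound 3 (`CO[C@H]1C(=O)N2C(C(=O)c3ccccc3)=C(CSc3nnnn3C)CS(=O)(=O)[C@H]12`). The change is hydrogen in place of (1-methyl-1H-tetrazol-5-yl)sulfanyl on a saturated ring carbon and amounts to hydrogen in place of (1-methyl-1H-tetrazol-5-yl)sulfanyl on a saturated ring carbon, next to the ring sulfur.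

Among the measured compounds shown here, only one measured step bears on this: a number 1.30 log units lower from compound 1 to compound 2 (beyond the scatter) is large and adds the same group, though at a saturated chain carbon and not at this ring carbon. For the measured compounds named here, no step at the ring carbon itself has been measured, so the comparison is only an analogy, and its size carries over with real uncertainty. Going by compound 2 and its step of a number 1.30 log units lower from compound 1 to compound 2 (beyond the scatter) as the guide, removal of the group is expected to raise the number by a large step beyond the scatter. The estimated move is a number 1.50 log units higher from compound 2 to compound 3 (beyond the scatter) in this reading. For compound 3 the expected value is 5 with an estimated range from 4.2 to 6 as the working figure.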

Compound 3, acid dissociation constant: 8.4
The estimate for compound 3 lay 3.40 log units below the measured number, outside the stated range (above it).
By their numbers in this assay, from the lowest: compound 2; then compound 1; then compound 3.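

In this assay, among these compounds, hydrogen in place of (1-methyl-1H-tetrazol-5-yl)sulfanyl on the saturated ring carbon, next to the ring sulfur, gives a number 4.90 log units higher from compound 2 to compound 3 (beyond the scatter) and so provides the first measured step at this position. The direction agrees with the reverse of the step on the saturated chain carbon, but that step, a number 1.30 log units lower from compound 1 to compound 2 (beyond the scatter) on adding the same group, is much smaller, so the size of a change at one place does not carry over to the other. Nothing available here accounts for the size of the step at the ring carbon.

The compounds shown leave open how the saturated ring carbon responds to other groups, such as a chlorine atom, a methoxy group or a smaller methylsulfanyl group, and therefore whether the large step belongs to the (1-methyl-1H-tetrazol-5-yl)sulfanyl group in particular or would appear with any replacement of hydrogen there. Going by these compounds, it also remains open whether the step keeps its size when the ((1-methyl-1H-tetrazol-5-yl)sulfanyl)methyl group is replaced by a plain methyl group or by a longer chain.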